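This account rests on a few compounds, and the source may have more. Where it says the series, first, only, none or still open, it means among the compounds named here.

Measured compounds:
compound 1, `CCn1c(/C=C2/C(=O)Nc3ccccc32)nc2ccccc21`, 38000 nM
compound 2, `CC(C)n1c(/C=C2/C(=O)Nc3ccc(F)cc32)nc2ccccc21`, 20800 nM

In a functional assay on PC-3 cells (Homo sapiens) for cytotoxicity, read by MTT assay, with a stated time of 48 h (a higher number here means a weaker inhibitor, a lower number a stronger inhibitor), compound 1 gives 38000 nM and compound 2 gives 20800 nM. Compound 2 has the lower of the two numbers, but its gap to compound 1 lies within the scatter, so no order between them is claimed. Compound 3, `CCn1c(/C=C2/C(=O)Nc3ccc(F)cc32)nc2ccccc21`, is not yet measured in this assay. It differs from compound 2 in one place: hydrogen in place of methyl on a saturated chain carbon bound to an aromatic nitrogen and a saturated chain carbon. Among the compounds with values here, no measured pair shows this change, so the step from compound 2 to compound 3 is expected to be small, in no particular direction, and not beyond the scatter: a 1.2-fold higher number from compound 2 to compound 3 (0.08 log units; within the scatter). Compound 3 is therefore expected to give about 25000 nM, between 10000 nM and 60000 nM.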

Compound 3, half-maximal inhibitory concentration: > 50000 nM
Compound 3: only a limit was reported (the forecaster's own chance of this, stated with the estimate: 10%); middle value at least 2.0-fold (0.30 log units) from the limit.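

In this assay compound 3 is reported only as a limit: the limit of > 50000 nM in this assay, at which 1 of the 3 values shown sits. Within the data shown here, the change from isopropyl to ethyl gives an at least 2.4-fold higher number from compound 2 to compound 3 (0.38 log units; beyond the scatter), the first readable step at this position, and it shows that the number responds to this change. Fluoro in place of hydrogen on an aromatic carbon gives an at least 1.3-fold higher number from compound 1 to compound 3 (0.11 log units; that floor lies within the scatter), so the size of that change stays unsettled. On these data alone, the true size of both steps remains open, since each rests on a limit. Also open, as far as these compounds go, is whether a longer chain or an amine-bearing chain in this place would lower the number further.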